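Moving the methoxy group on the aryl ether

This account rests on a few compounds, and the source may have more. Where it says the series, first, only, none or still open, it means among the compounds named here.

Compound 1 `COc1cccc(OC/C=C(\C)CC/C=C(\C)C2CC(=O)C(C)(C)O2)c1` and compound 2 `COc1cccc(OC/C=C(\C)CC/C=C(\C)C2=CC(=O)C(C)(C)O2)c1` share one core and differ only in the five-membered ring at the chain end. In a functional assay on MT4 cells (Homo sapiens) for inhibition (a higher number here means a weaker inhibitor, a lower number a stronger inhibitor), compound 1 gives 51.5 ug/mL, and compound 2 gives 34 ug/mL; the step of a 1.5-fold lower number from compound 1 to compound 2 (0.18 log units; within the scatter) lies within the scatter. Compound 2 therefore stands beside compound 1, its number not distinguishable from it. Compound 3 `COc1ccc(OC/C=C(\C)CC/C=C(\C)C2=CC(=O)C(C)(C)O2)cc1` differs from compound 2 by 4-methoxyphenyl in place of 3-methoxyphenyl on an oxygen on a saturated carbon. Among the measured compounds shown here, no measured step touches this change, so nothing beyond the scatter is expected. Compound 3 is estimated at 34 ug/mL, between 15 ug/mL and 80 ug/mL, an expected step of no change at the digits printed from compound 2 to compound 3 (within the scatter).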

Compound 3, half-maximal inhibitory concentration: 33.9 ug/mL
Beside the measured number, compound 3's estimate is 1.0-fold (0.00 log units) above it, and the stated range covers the measured number.
By their numbers in this assay, from the lowest: compounds 3, 2 and 1 (each within the scatter of the next).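

Among the compounds shown here, replacing 3-methoxyphenyl with 4-methoxyphenyl on the oxygen gives a 1.0-fold lower number from compound 2 to compound 3 (0.00 log units; within the scatter) in this assay and is the first measured change at the aryl ether end, since the earlier pair differed only in the five-membered ring. At this position, the two methoxyphenyl groups cannot be told apart by their numbers. No measurement here explains this result.

From the compounds shown here alone, what remains open is whether a different group on this aromatic ring, such as an amine or a carboxylic acid, would move the number beyond the scatter. Replacing the methoxy group with a longer ether chain is equally unresolved.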